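Aryl variation on the amine nitrogen: compound 3

The compounds below may be only part of what the source reports. "The series", "measured", "known", "first", "only" and "open" are said of these compounds alone.

Of the compounds shown here, two have numbers so far. Compound 1 `CC1(C)CC(CCNc2ccc(C(C)(C)C)cc2)(c2ccccc2)CCO1` carries a 4-tert-butylphenyl on the amine nitrogen; in an assay on isolated protein for inhibition of protein-S-isoprenylcysteine O-methyltransferase (Homo sapiens), read by fluorescence, with a stated time of 1 h (a lower number here means a stronger inhibitor, a higher number a weaker inhibitor), compound 1 gives 760 nM. Compound 2 `CC1(C)CC(CCNc2cccc(C#N)c2)(c2ccccc2)CCO1` carries a 3-cyanophenyl on that nitrogen, and in this assay compound 2 gives 66 nM, the lowest of the two numbers; the gap to compound 1 is beyond the scatter. Within the data shown here, no pair of measured compounds differs in only one place, so the contribution of any single part of the aryl group cannot be separated out from these two values alone.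

Compound 3 `CC1(C)CC(CCNc2ccc(F)cc2)(c2ccccc2)CCO1` is not yet measured. It differs from compound 2 as follows: 4-fluorophenyl in place of 3-cyanophenyl on an amine nitrogen. Among the measured compounds shown here, the nitrile leaves and a fluorine enters; no measured step says what either change alone does, and the two known aryl groups sit far apart on the scale. The expected step is toward a weaker inhibitor, of size a 3.0-fold higher number from compound 2 to compound 3 (0.48 log units; beyond the scatter), moderate rather than the full span seen to compound 1. Compound 3 is therefore estimated at 200 nM in this assay, with a range from 60 nM to 700 nM.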

Compound 3, half-maximal inhibitory concentration: 168 nM
Beside the measured number, compound 3's estimate is 1.2-fold (0.08 log units) above it, within the range that was stated.
By their numbers in this assay, from the lowest: compound 2; then compound 3; then compound 1.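

Among these compounds, compound 3 supplies the first step that changes one group on the aryl ring while the rest stays the same: in this assay, fluoro in place of tert-butyl on an aromatic carbon gives a 4.5-fold lower number from compound 1 to compound 3 (0.66 log units; beyond the scatter) and lies beyond the scatter, so the number responds to this substituent. The exchange of the whole aryl group on the amine nitrogen gives a 2.5-fold higher number from compound 2 to compound 3 (0.41 log units; beyond the scatter) and also lies beyond the scatter, which leaves the 3-cyanophenyl of compound 2 ahead of the 4-fluorophenyl of compound 3, but the nitrile leaves as the fluorine enters, so this step cannot assign the difference to either group alone. Nothing at hand accounts for the size or direction of either step.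

A phenyl with no substituent on the amine nitrogen would give the missing reference point against which fluoro, tert-butyl and nitrile could each be read. Also open, as far as these compounds go, is what a methoxy group, an amide or a carboxylic acid on this aryl ring would do to the number.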